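Replacing a Methoxyphenyl Ether with a tert-Butylphenyl Ether

The source may report more compounds than this note shows. Statements on the series, on what has been measured and on what is new or still open speak of the compounds shown alone.

Three compounds have been measured in a functional assay on MCF7 cells (Homo sapiens) for antiproliferative activity; on this read-out higher numbers stand for weaker inhibition and lower numbers for stronger inhibition:

Compound 1, `COc1ccc(Oc2ccc3cc(NC(=O)c4ccc(OC(C)=O)c(CC=C(C)C)c4)c(=O)oc3c2C)cc1`, gives 18200 nM in this assay.
Compound 2, `COc1ccc(Oc2ccc3cc(NC(=O)c4ccc(OC)c(-c5cccc(OC)c5)c4)c(=O)oc3c2C)cc1`, reaches only the limit of > 100000 nM in this assay.
Compound 3, `COc1cccc(Oc2ccc3cc(NC(=O)c4ccc(OC)c(-c5cccc(OC)c5)c4)c(=O)oc3c2C)c1`, also reaches only the limit of > 100000 nM in this assay.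

Compound 3 therefore stands at the limit of > 100000 nM in this assay, at which 2 of the 3 values shown sit, so no number is known for it, only that it is weaker than the assay can read. Within the data shown here, the one step between measured neighbours, a step that the two limits leave unreadable from compound 2 to compound 3, cannot be sized because both of its ends sit at the limit of > 100000 nM in this assay, at which 2 of the 3 values shown sit. Among the measured compounds shown here, compound 1 is the only compound with a readable number, but it differs from compound 3 in more than one place, so no single step connects them.

Compound 4, `COc1cccc(-c2cc(C(=O)Nc3cc4ccc(Oc5ccc(C(C)(C)C)cc5)c(C)c4oc3=O)ccc2OC)c1`, differs from compound 3 by 4-(tert-butyl)phenyl in place of 3-methoxyphenyl on an oxygen on an aromatic ring. For the measured compounds named here, no measured step bears on this exchange, since the only recorded step is unreadable. With compound 3 at the limit and nothing measured that speaks for a gain, compound 4 is expected to remain weak, and most likely to be reported again as a limit. The step of a number no higher from compound 3 to compound 4 (the limit leaves the size open) is therefore estimated to be no larger than the scatter. Compound 4 is estimated at 100000 nM, within a range of 30000 nM to 300000 nM.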

Compound 4, half-maximal inhibitory concentration: > 100000 nM
Compound 4: only a limit was reported; the forecaster's own chance of this, stated with the estimate: 65%; the middle value sits exactly at the limit.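

The steps from compound 2 and from compound 3 to compound 4 cannot be read, since all three compounds end at one and the same limit, which is not a number: the limit of > 100000 nM in this assay, at which 3 of the 4 values shown sit. Going by these compounds, whether 4-(tert-butyl)phenyl in place of a methoxyphenyl changes the activity at all stays open, as compound 2, compound 3 and compound 4 have no readable number.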